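The source may report more compounds than this note shows. Statements on the series, on what has been measured and on what is new or still open speak of the compounds shown alone.

For the measured compounds named here, compound 2, whose structure is `O=S(=O)(CC1=NCCS1)c1c[nH]cc1S(=O)(=O)c1ccc(Cl)cc1`, holds the lower of the two numbers measured so far. In a functional assay for inhibition, tested at 100 uM (on this read-out higher numbers stand for more inhibition at the one concentration tested (going by the name of the read-out) and lower numbers for less inhibition), compound 2 gives 41.4%, while compound 1, with the structure `O=S(=O)(CC1=NCCO1)c1c[nH]cc1S(=O)(=O)c1ccc(Cl)cc1`, gives 92.1% in the same test. Going by the values given here, the single measured step is a number 50.7 percentage points lower from compound 1 to compound 2 (beyond the scatter). The difference between these two compounds sits at the saturated chain carbon bound to a sulfonyl sulfur, and this step is the only one recorded.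

Compound 3, with the structure `Cc1ccc(S(=O)(=O)c2c[nH]cc2S(=O)(=O)CC2=NCCS2)cc1`, is the next member to be tested. Its difference from compound 2 is methyl in place of chloro on an aromatic carbon. Among the compounds with values here, this change sits on the six-membered aromatic ring of carbon only, a different place from the one varied between compound 1 and compound 2, so the one measured step does not bear on it directly. Within the data shown here, with no step of this kind on record, the expected step in this assay from compound 2 to compound 3 is none beyond the scatter, namely a number 0.4 percentage points lower from compound 2 to compound 3 (within the scatter). Compound 3 is therefore estimated at 41%, within a range from 18% to 66%.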

Compound 3, a percentage reported as inhibition, at one concentration (the size of the read-out at that concentration, not a potency): 23.7%
Compound 3: middle estimate off by 17.3 percentage points, on the high side; measured number inside the range.
By their numbers in this assay, from the lowest: compound 3; then compound 2; then compound 1.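

The 4-chlorophenyl end of the molecule, unchanged between the two earlier compounds, proves not to be silent in this assay: exchanging chloro for methyl on an aromatic carbon of the six-membered aromatic ring gives a number 17.7 percentage points lower from compound 2 to compound 3 (beyond the scatter), a modest step. The read-out therefore responds at this position as well as at the saturated chain carbon bound to a sulfonyl sulfur, and it does so for an exchange of one heavy atom for one heavy atom, where neither group carries a ring, a hydrogen-bond donor, a hydrogen-bond acceptor or a net charge. No measured property is available here to account for this step.

Whether 4-chlorophenyl to 4-methylphenyl would read the same way on compound 1, with its oxygen-containing five-membered ring, remains open, as the one exchange shown stands on the sulfur-containing ring of compound 2. With only chloro and methyl at this place, the compounds shown also leave open what a fluoro group, a methoxy group, an amine or a carboxylic acid would give there.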